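The source may hold more compounds than are shown below. What is called first, only, known or untested is meant among the compounds shown, and "the series" means these compounds.

Four compounds are compared in a functional assay on HeLa S3 cells (Homo sapiens) for antiproliferative activity, read by XTT assay, with a stated time of 72 h; on this read-out higher numbers stand for weaker inhibition and lower numbers for stronger inhibition. Compound 1 `C#Cc1cn([C@@H]2O[C@H](CO)[C@@H](O)[C@H]2O)c2nc(C)nc(N)c12` gives only a limit in this assay, > 20000 nM, and the limit of > 20000 nM in this assay, at which 1 of the 3 values shown sits, is the limit at which that value sits. Compound 2 `Cc1nc(N)c2c(I)cn([C@@H]3O[C@H](CO)[C@@H](O)[C@H]3O)c2n1` carries the change iodo in place of ethynyl on an aromatic carbon and gives 4180 nM in this assay, so that the step of an at least 4.7-fold lower number from compound 1 to compound 2 (0.67 log units; beyond the scatter) runs clearly beyond the scatter. Compound 3 `C#Cc1cn([C@@H]2O[C@H](CO)[C@@H](O)[C@H]2O)c2ncnc(OC)c12` keeps the ethynyl group but stands on a different core; the difference between the two cores is not broken down here. In this assay compound 3 gives 1730 nM, the lowest of the two numbers that are not limits. Compound 4 `COc1ncnc2c1c(I)cn2[C@@H]1O[C@H](CO)[C@@H](O)[C@H]1O` is not yet measured; it differs from compound 3 by iodo in place of ethynyl on an aromatic carbon, the same change that separates compound 1 from compound 2, made at the same place. On the strength of the earlier step of an at least 4.7-fold lower number from compound 1 to compound 2 (0.67 log units; beyond the scatter), the step of a 3.5-fold lower number from compound 3 to compound 4 (0.54 log units; beyond the scatter) is expected to run in the same direction, with some uncertainty about its size. Compound 4 is therefore estimated at 500 nM in this assay, expected to fall between 150 nM and 1700 nM.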

Compound 4, half-maximal inhibitory concentration: 14300 nM
Compound 4: the middle estimate sits 29-fold (1.46 log units) below what was measured, outside the stated range (above it).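

In this assay, iodo in place of ethynyl on the aromatic carbon gives an 8.3-fold higher number from compound 3 to compound 4 (0.92 log units; beyond the scatter), and the step does not carry over from the core of compound 1 to the core of compound 3: the same change on two cores in this assay, an at least 4.7-fold lower number (0.67 log units; beyond the scatter) from compound 1 to compound 2 and an 8.3-fold higher number (0.92 log units; beyond the scatter) from compound 3 to compound 4, at least 39-fold (1.59 log units) apart, beyond the scatter of two such steps Compound 1 gives > 20000 nM, which is a limit of the assay and not a number, so the earlier step has no exact size: the limit of > 20000 nM in this assay, at which 1 of the 4 values shown sits. These two pairs show that the direction of this change differs between the two cores, but they do not show which difference between the cores goes with the reversal or how the change would run on any further core.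

The compounds shown leave open how a bromo group, a nitrile or a longer chain on the same aromatic carbon would compare with ethynyl and iodo on either core. Also open, on these data alone, is how the exchange would run with a chloro group or a thiol in place of the methoxy group of compound 3.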